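Aryl exchange on the shared core: compound 2 to compound 3

The source may hold more compounds than are shown below. What is called first, only, known or untested is meant among the compounds shown, and "the series" means these compounds.

- compound 1 `CC1(C)[C@H]2CC[C@]1(C)N(Cc1cn(-c3cccc(F)c3)nn1)C(=O)C2` gives 220 nM
- compound 2 `CC1(C)[C@H]2CC[C@]1(C)N(Cc1cn(-c3ccccc3Br)nn1)C(=O)C2` gives 280 nM

Within the data shown here, in a functional assay on PANC-1 cells (Homo sapiens) for inhibition, read by MTT assay, with a stated time of 24 h (a lower number here means a stronger inhibitor, a higher number a weaker inhibitor), compound 2 at 280 nM stands within the scatter of compound 1, its only measured neighbour, so the two cannot be ordered.

The next change leads to compound 3 `CC1(C)[C@H]2CC[C@]1(C)N(Cc1cn(-c3ccc(C#N)cc3)nn1)C(=O)C2` and is 4-cyanophenyl in place of 2-bromophenyl on an aromatic nitrogen, with 4-cyanophenyl in place of 2-bromophenyl on an aromatic nitrogen. Among the measured compounds shown here, one measured step bears on it: a 1.3-fold higher number from compound 1 to compound 2 (0.10 log units; within the scatter), also an exchange of the aryl group on that nitrogen. For the measured compounds named here, that step is small, but no measured compound carries the 4-cyanophenyl group, so the evidence is thin. No step beyond the scatter is expected in this assay, and no direction can be given.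

The expected step is a 1.1-fold lower number from compound 2 to compound 3 (0.05 log units; within the scatter) and is read as no real shift.

For compound 3 the estimated value is 250 nM, with 100 nM to 650 nM as the expected range.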

Compound 3, half-maximal inhibitory concentration: 250 nM
Estimate against measurement, compound 3: no gap at the digits printed; the measured number falls inside the stated range.
By their numbers in this assay, from the lowest: compounds 1, 3 and 2 (each within the scatter of the next).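

In this assay the 4-cyanophenyl group brings a nitrile and a hydrogen-bond acceptor onto the aromatic nitrogen, and replacing 2-bromophenyl with it gives (a 1.1-fold lower number from compound 2 to compound 3 (0.05 log units; within the scatter)), while replacing 3-fluorophenyl with it gives (a 1.1-fold higher number from compound 1 to compound 3 (0.06 log units; within the scatter)). The three aryl groups on this nitrogen therefore cannot be ordered, and the position accepts a nitrile-bearing ring as readily as either halogen-bearing ring, with no step beyond the scatter. Nothing on hand offers a reason for this flat reading.

Open, from the compounds shown here alone, is whether an amine or a carboxylic acid on the phenyl ring, or a longer alkyl chain in place of the ring, would move the number beyond the scatter. Also open, going by these compounds, is whether the same flat reading would hold on the shared core in other cell lines.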